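Swapping trifluoromethyl for sulfamoyl in compound 3

The source may report more compounds than this note shows. Statements on the series, on what has been measured and on what is new or still open speak of the compounds shown alone.

In an ADME assay on MT4 cells (Homo sapiens) for cytotoxicity, read by MTT assay, with a stated time of 5 days (a higher number here means that more compound is tolerated, a lower number that less compound is tolerated), compound 1 `COc1cc2nc([S+]([O-])CC(=O)Nc3ccccc3F)nc(Nc3c(Cl)cc(/C=C/C#N)cc3Cl)c2cc1OC` reaches only the limit > 208000 nM and gives no number. Compound 2 `COc1cc2nc([S+]([O-])CC(=O)Nc3ccccc3C(F)(F)F)nc(Nc3c(Cl)cc(/C=C/C#N)cc3Cl)c2cc1OC` also reaches only a limit, > 192000 nM and no number. Going by the values given here, compound 3 `COc1cc2nc([S+]([O-])CC(=O)Nc3cccc(C(F)(F)F)c3)nc(Nc3c(Cl)cc(/C=C/C#N)cc3Cl)c2cc1OC` gives 21800 nM as the only number so far. Compound 4 `COc1cc2nc([S+]([O-])CC(=O)Nc3cccc(S(N)(=O)=O)c3)nc(Nc3c(Cl)cc(/C=C/C#N)cc3Cl)c2cc1OC` carries sulfamoyl in place of trifluoromethyl on an aromatic carbon meta to a large group. Among the compounds with values here, no measured step makes this swap. The nearest are an at least 9.5-fold lower number from compound 1 to compound 3 (0.97 log units; beyond the scatter) and an at least 8.8-fold lower number from compound 2 to compound 3 (0.94 log units; beyond the scatter) on the amide-type nitrogen, while a step that the two limits leave unreadable from compound 1 to compound 2 is unreadable. Losing the 3-(trifluoromethyl)phenyl group is therefore expected to recover part of that drop. The expected step is a 1.8-fold higher number from compound 3 to compound 4 (0.26 log units; within the scatter) in this assay and remains modest. Compound 4 is estimated at 40000 nM with 12000 nM to 130000 nM as its likely range.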

Compound 4, half-maximal cytotoxic concentration: 67800 nM
Estimate against measurement, compound 4: 1.7-fold (0.23 log units) below; the range from low to high includes it.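

In this assay, sulfamoyl in place of trifluoromethyl on this aromatic carbon, meta to a large group, gives a 3.1-fold higher number from compound 3 to compound 4 (0.49 log units; beyond the scatter), so the drop seen with compound 3 depends on the group carried here and not on the place alone. The recovery is only partial, with an at least 2.8-fold lower number from compound 2 to compound 4 (0.45 log units; beyond the scatter) and an at least 3.0-fold lower number from compound 1 to compound 4 (0.48 log units; beyond the scatter). Both of these steps start from a limit and give only a bound.

The compounds shown leave open whether a carboxylic acid or an amine at this place would fall nearer compound 3 or nearer compound 4. What causes the step cannot be read from them.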